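The source may report more compounds than this note shows. Statements on the series, on what has been measured and on what is new or still open speak of the compounds shown alone.

In a functional assay on MCF7 cells (Homo sapiens) for antiproliferative activity, read by MTT assay (on this read-out higher numbers stand for weaker inhibition and lower numbers for stronger inhibition), compound 1 `COc1ccc(-c2nc(N3CCNCC3)nc3ccccc23)c(OC)c1` gives 50 ug/mL, level with compound 2 `CN1CCN(c2nc(-c3cn(C)c4ccccc34)c3ccccc3n2)CC1` at 50 ug/mL. Compound 3 `COc1ccc(-c2nc(N3CCN(C)CC3)nc3ccccc23)c(OC)c1` differs from compound 1 by methyl in place of hydrogen on an amine nitrogen in a ring, which turns piperazin-1-yl into 4-methylpiperazin-1-yl. Within the data shown here, no measured pair shows this change alone. Compound 2 also carries 4-methylpiperazin-1-yl and gives 50 ug/mL, so little movement is expected in this assay. The expected step of no change at the digits printed from compound 1 to compound 3 (within the scatter) stays within the scatter, with no direction favoured. Compound 3 is estimated at 50 ug/mL, with an expected range of 22 ug/mL to 100 ug/mL.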

Compound 3, half-maximal inhibitory concentration: 50 ug/mL
Compound 3: the middle estimate sits on the measured number at the digits printed, and the stated range covers the measured number.
By their numbers in this assay, from the lowest: compounds 1, 2 and 3 (each within the scatter of the next).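

In this assay, among these compounds, methyl in place of hydrogen on an amine nitrogen in a ring gives no change at the digits printed from compound 1 to compound 3 (within the scatter), and this pair is the only one that shows the change alone. On the core of compound 1, this read-out therefore does not separate piperazin-1-yl from 4-methylpiperazin-1-yl. No supporting data bear on this result. On these data alone, whether the same change behaves alike on the core of compound 2 stays open. So does the effect of an ethyl, an acetyl or a longer chain on that nitrogen.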